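Swapping the aniline substituent in a triazolopyridine series

The source may report more compounds than this note shows. Statements on the series, on what has been measured and on what is new or still open speak of the compounds shown alone.

Compound 1 `CC(C)Nc1ccc(-c2ccn3c(CC4CC4)nnc3c2C(F)(F)F)cc1F` was tested in an assay on cells for displacement of a labelled ligand from metabotropic glutamate receptor 2 (Homo sapiens), read by scintillation counting, with a stated time of 60 min (on this read-out lower numbers stand for stronger inhibition and higher numbers for weaker inhibition), where compound 1 gives 8.91 nM. Among the compounds with values here, its closest neighbour, compound 2 `CC(C)Nc1ccc(-c2ccn3c(CC4CC4)nnc3c2C(F)(F)F)cc1Cl`, gives 3.89 nM; the only measured step is a 2.3-fold lower number from compound 1 to compound 2 (0.36 log units; beyond the scatter), which leaves compound 1 with the highest of the two numbers recorded so far. Compound 3 `COc1ccc(COc2ccc(-c3ccn4c(CC5CC5)nnc4c3C(F)(F)F)cc2F)cn1` has not yet been measured. It differs from compound 1 by (6-methoxypyridin-3-yl)methoxy in place of isopropylamino on an aromatic carbon. Within the data shown here, no measured step concerns this position or a change of this kind; the step from compound 1 to compound 2 touches only the halogen and gives no guide to the size or direction of a swap of the amino group for an ether. Compound 3 is therefore expected to stay close to compound 1, with a wide band of uncertainty, its estimated value being 6 nM (range 1.5 nM to 30 nM), a step of a 1.5-fold lower number from compound 1 to compound 3 (0.17 log units; within the scatter).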

Compound 3, inhibition constant: 11.8 nM
The estimate for compound 3 lay 2.0-fold (0.29 log units) below the measured number; the range from low to high includes it.
By their numbers in this assay, from the lowest: compound 2; then compounds 1 and 3 (each within the scatter of the next).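

On this aromatic carbon, ortho to a fluoro group, (6-methoxypyridin-3-yl)methoxy in place of isopropylamino gives a 1.3-fold higher number from compound 1 to compound 3 (0.12 log units; within the scatter) in this assay. Within the data shown here, the first structural change at this position therefore leaves the number within the scatter, although the entering group brings a six-membered aromatic ring and 0 hydrogen-bond donors, where the leaving group has no ring and 1 donor. Nothing available bears on why the two compounds read alike.

On these data alone, it remains open whether the same swap would read alike with the chloro group of compound 2 in place of fluoro. Also open, as far as these compounds go, is how a plain methoxy group, a benzyloxy group or an amine carrying the same (6-methoxypyridin-3-yl)methyl group would read, so the ether oxygen and the ring nitrogen cannot yet be separated.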